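From Chloro to Bromo: Cytotoxicity on Vero Cells

The source may report more compounds than this note shows. Statements on the series, on what has been measured and on what is new or still open speak of the compounds shown alone.

Compound 1 `Fc1ccc([C@@H]2C[C@@H]3Cc4ccc5ccccc5c4N2O3)cc1` and compound 2 `Clc1cccc([C@@H]2C[C@@H]3Cc4ccc5ccccc5c4N2O3)c1` share one core and differ only in the aryl group on a saturated ring carbon. In an ADME assay on Vero cells (Chlorocebus sabaeus) for cytotoxicity, read by MTT assay, with a stated time of 72 h (on this read-out higher numbers stand for lower toxicity in this test and lower numbers for higher toxicity in this test), compound 1 gives > 300000 nM, which is a limit of the assay rather than a number. In this assay compound 2 likewise gives > 300000 nM, again a limit. The step that the two limits leave unreadable from compound 1 to compound 2 therefore cannot be sized, since both values sit at the limit of > 300000 nM in this assay, at which 2 of the 2 values shown sit. Compound 2 thus stands at the limit itself, with no number to set it apart from compound 1. Compound 3 `Brc1cccc([C@@H]2C[C@@H]3Cc4ccc5ccccc5c4N2O3)c1` differs from compound 2 by bromo in place of chloro on an aromatic carbon. Going by the values given here, the single measured step concerns another position and is unreadable, so it offers no direction. On that basis compound 3 is expected to show a step that the limit leaves unreadable from compound 2 to compound 3, that is, no change beyond the scatter. The estimate for compound 3 is 400000 nM, within 150000 nM to 1000000 nM.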

Compound 3, half-maximal cytotoxic concentration: > 250000 nM
Compound 3 gave a limit, no number; the forecaster's own chance of this, stated with the estimate: 85%; the middle value lies beyond the limit too.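

In this assay compound 3 gives > 250000 nM, a limit of the assay and not a number. Going by these compounds alone, compound 1, compound 2 and compound 3 all stand at limits, and no step among them can be read. The compounds shown leave open whether the aryl group affects this read-out at all.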